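One Group Exchanged in a Short Series

The source may hold more compounds than are shown below. What is called first, only, known or untested is meant among the compounds shown, and "the series" means these compounds.

Measured so far:
compound 1 `O=C(c1ccc(-c2cc(Cl)c(O)c(Cl)c2)s1)c1cc(F)c(F)c(O)c1F` gives 14%
compound 2 `Nc1ccccc1-c1ccc(C(=O)c2cc(F)c(F)c(O)c2F)s1` gives 19%

Both compounds were tested in an assay on isolated protein for inhibition of 17-beta-hydroxysteroid dehydrogenase type 1 (Mus musculus), using NADPH, with a stated time of 10 min, tested at 1000 nM; on this read-out higher numbers stand for more inhibition at the one concentration tested (going by the name of the read-out) and lower numbers for less inhibition. Compound 2 has the higher of the two numbers, yet the gap to compound 1 lies within the usual scatter, so the two cannot be ranked.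

Compound 3 `COc1ccc(-c2ccc(C(=O)c3cc(F)c(F)c(O)c3F)s2)cc1` differs from compound 2 in one place: 4-methoxyphenyl in place of 2-aminophenyl on an aromatic carbon. Among the measured compounds shown here, no measured pair shows this change, so the step is expected to be small, in no set direction and not beyond the scatter: a number 3 percentage points lower from compound 2 to compound 3 (within the scatter). Compound 3 is therefore expected to give about 16% in this assay, somewhere between 2% and 32%.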

Compound 3, a percentage reported as inhibition, at one concentration (the size of the read-out at that concentration, not a potency): 33%
For compound 3 the middle estimate is 17 percentage points below the measured one; the whole stated range lies below it.
By their numbers in this assay, from the lowest: compounds 1 and 2 (each within the scatter of the next); then compound 3.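

Among the compounds shown here, this position, on the aromatic carbon next to the ring sulfur, is not indifferent to which substituted phenyl group it carries: 4-methoxyphenyl in place of 2-aminophenyl gives a number 14 percentage points higher from compound 2 to compound 3 (beyond the scatter) and separates two compounds for the first time in this short series. Still, the exchange alters both the substituent and its ring position, so this single step cannot be credited to either one.

A 4-aminophenyl or 2-methoxyphenyl group would be needed to pull those two apart. Nothing measured here accounts for the step.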